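The source may hold more compounds than are shown below. What is called first, only, known or untested is meant among the compounds shown, and "the series" means these compounds.

Measured so far:
compound 1, `CCC(=O)Nc1c(C(O)(C(F)(F)F)C(F)(F)F)ccc2ccccc12`, 15 nM;
compound 2, `O=C(Nc1c(C(O)(C(F)(F)F)C(F)(F)F)ccc2ccccc12)C1CCCC1`, 495 nM;
compound 3, `COCC(=O)Nc1c(C(O)(C(F)(F)F)C(F)(F)F)ccc2ccccc12`, 213 nM.

All three share one core and differ only in the group on the amide carbonyl. In an assay on LtK cells with ATP-sensitive inward rectifier potassium channel 11 (Homo sapiens) as the target (a lower number here means that less compound is needed, a higher number that more compound is needed for the effect), compound 1 gives the lowest number of the set, and compound 3 stands second highest: its nearest neighbour is compound 2, with a 2.3-fold lower number from compound 2 to compound 3 (0.37 log units; beyond the scatter), and its furthest is compound 1, with a 14-fold higher number from compound 1 to compound 3 (1.15 log units; beyond the scatter).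

Compound 4, `O=C(Nc1c(C(O)(C(F)(F)F)C(F)(F)F)ccc2ccccc12)c1ccccc1Cl`, has not yet been measured. Its change from compound 3 is 2-chlorophenyl in place of methoxymethyl on a carbonyl carbon. For the measured compounds named here, the steps that bear on it are those where the group on the carbonyl grows: a 33-fold higher number from compound 1 to compound 2 (1.52 log units; beyond the scatter) and a 14-fold higher number from compound 1 to compound 3 (1.15 log units; beyond the scatter). Both large groups gave markedly higher numbers than the ethyl of compound 1, and the ring of compound 2 gave the highest number of all. The 2-chlorophenyl entering in compound 4 is again a ring and larger than what it replaces, so a higher number is expected, a 3.3-fold higher number from compound 3 to compound 4 (0.52 log units; beyond the scatter). The estimate for compound 4 in this assay is therefore 700 nM, within 150 nM to 3500 nM.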

Compound 4, half-maximal effective concentration: 2040 nM
Compound 4: middle estimate off by 2.9-fold (0.46 log units), on the low side, within the range that was stated.
By their numbers in this assay, from the lowest: compound 1; then compound 3; then compound 2; then compound 4.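

In this assay, cyclopentyl does not mark the upper end at this carbonyl carbon: 2-chlorophenyl goes further, with a 4.1-fold higher number from compound 2 to compound 4 (0.62 log units; beyond the scatter), so the two ring-bearing groups do not behave alike. The change from methoxymethyl gives a 9.6-fold higher number from compound 3 to compound 4 (0.98 log units; beyond the scatter), and the change from ethyl gives a 140-fold higher number from compound 1 to compound 4 (2.13 log units; beyond the scatter), the widest step in the set at this single position. Among these four compounds, each of the three larger groups gives a higher number than ethyl, and none goes against that. No measurement at hand accounts for these differences.

From the compounds shown here alone, what a plain phenyl group on the same carbonyl carbon would give remains open, and with it whether the ring or the chlorine carries the step. Also open, going by these compounds, is how a methyl group or a longer straight chain would compare with ethyl.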